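The source may hold more compounds than are shown below. What is called first, only, known or untested is meant among the compounds shown, and "the series" means these compounds.

Within the data shown here, compound 2 `Cc1ccc(OC(=O)Nc2ccc([Se]C#N)cc2)cc1` is one of two compounds measured here, and in a functional assay on PC-3 cells (Homo sapiens) for cytotoxicity, read by MTT assay, with a stated time of 72 h (on this read-out higher numbers stand for weaker inhibition of growth and lower numbers for stronger inhibition of growth), compound 2 gives 7600 nM. This is the higher of the two numbers, but only just: its neighbour, compound 1 `COc1ccc(OC(=O)Nc2ccc([Se]C#N)cc2)cc1`, gives 7500 nM in this assay, and the step of a 1.0-fold higher number from compound 1 to compound 2 (0.01 log units; within the scatter) is too small to count as a real difference. That step swapped methyl for methoxy on an aromatic carbon of the outer ring.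

Compound 3 `N#C[Se]c1ccc(NC(=O)Oc2ccccc2)cc1` has not yet been measured in this assay. It differs from compound 2 in one place: hydrogen in place of methyl on an aromatic carbon, that is, the methyl group leaves and a hydrogen takes its place on the aromatic carbon that sits para to a large group. Among the measured compounds shown here, the only measured step that bears on this position is the one from compound 1 to compound 2, which stayed within the scatter. So the expectation is that removing the methyl also moves the number little, with a step of no change at the digits printed from compound 2 to compound 3 (within the scatter) that is estimated to stay within the scatter. For compound 3 the estimated value in this assay is 7600 nM, with an expected range from 3800 nM to 15000 nM.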

Compound 3, concentration for 50% growth inhibition: 9100 nM
Compound 3: middle estimate off by 1.2-fold (0.08 log units), on the low side; the measured number falls inside the stated range.
By their numbers in this assay, from the lowest: compounds 1, 2 and 3 (each within the scatter of the next).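

In this assay hydrogen in place of methyl gives a 1.2-fold higher number from compound 2 to compound 3 (0.08 log units; within the scatter) and hydrogen in place of methoxy gives a 1.2-fold higher number from compound 1 to compound 3 (0.08 log units; within the scatter) so neither step can be read as a real difference. Among these compounds, until now, the only comparison at this position was between two groups, methyl and methoxy, so it could not say whether having any group there mattered. Now that the unsubstituted compound is included, it can be said that, among these three compounds, the aromatic carbon para to a large group gives the same result within the scatter whether it carries methoxy, methyl or only hydrogen.

From the compounds shown here alone, whether that would hold for a quite different group on the same carbon, such as an amine, a carboxylic acid or a longer chain like butyl, remains open, since the three compounds cover only hydrogen, methyl and methoxy. The data also offer no explanation for the absence of a readable difference among these three compounds.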